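A few compounds are considered here, and "the series" means these few. Any claim that something is new, unique, unknown or untested is made for them only; others in the source may bear on it.

Compound 2 `Cc1cc(-c2nc(C(F)(F)F)ccc2CNC(=O)C(C)c2ccc(NS(C)(=O)=O)c(F)c2)ccc1F` sets the reference point here. In an assay on CHO cells for antagonist activity at transient receptor potential cation channel subfamily V member 1 (Homo sapiens), read by FLIPR (a higher number here means a weaker inhibitor, a lower number a stronger inhibitor), compound 2 gives 0.4 nM, the lowest of the three numbers seen, though compound 1 `CC(C(=O)NCc1ccc(C(F)(F)F)nc1-c1ccc(Cl)cc1)c1ccc(NS(C)(=O)=O)c(F)c1`, which gives 0.7 nM, lies within the scatter of it (a 1.8-fold lower number from compound 1 to compound 2 (0.24 log units; within the scatter)). Compound 3 `CC(C(=O)NCc1ccc(C(F)(F)F)nc1-n1ccnc1)c1ccc(NS(C)(=O)=O)c(F)c1` gives 36.1 nM and stands far apart, with a 52-fold higher number from compound 1 to compound 3 (1.71 log units; beyond the scatter) and a 90-fold higher number from compound 2 to compound 3 (1.96 log units; beyond the scatter).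

Compound 4 `CC(C(=O)NCc1ccc(C(F)(F)F)nc1-c1ccc2cc[nH]c2c1)c1ccc(NS(C)(=O)=O)c(F)c1` is the unmeasured compound. It differs from compound 2 at one place: 1H-indol-6-yl in place of 4-fluoro-3-methylphenyl on an aromatic carbon.

The two steps that bear on this change both start from an aryl group on the same aromatic carbon. The exchange of one six-membered aryl for another, a 1.8-fold lower number from compound 1 to compound 2 (0.24 log units; within the scatter), stayed within the scatter, whereas the exchange for a five-membered heteroaryl, a 90-fold higher number from compound 2 to compound 3 (1.96 log units; beyond the scatter), cost a great deal. The entering 1H-indol-6-yl keeps a six-membered aromatic ring of carbon only at the point of attachment and adds a fused five-membered ring with one nitrogen and a hydrogen-bond donor. He therefore expects a step in this assay smaller than that to compound 3 but larger than that to compound 1, going toward a higher number. For compound 4 the estimate in this assay is 3 nM, in a range from 0.6 nM to 15 nM, which means an expected step of a 7.5-fold higher number from compound 2 to compound 4 (0.88 log units; beyond the scatter).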

Compound 4, inhibition constant: 20.3 nM
Estimate against measurement, compound 4: 6.8-fold (0.83 log units) below; the whole stated range lies below it.
By their numbers in this assay, from the lowest: compounds 2 and 1 (each within the scatter of the next); then compounds 4 and 3 (each within the scatter of the next).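

In this assay, among these compounds, this position on the aromatic carbon next to the ring nitrogen had so far tolerated an exchange of one substituted phenyl for another, and only the 1H-imidazol-1-yl group had cost much. Compound 4 shows that keeping a six-membered aromatic ring of carbon only at the point of attachment is not enough to hold the low numbers, with (a 51-fold higher number from compound 2 to compound 4 (1.71 log units; beyond the scatter)) and (a 29-fold higher number from compound 1 to compound 4 (1.46 log units; beyond the scatter)). The 1H-indol-6-yl group also ends up level with the 1H-imidazol-1-yl group (a 1.8-fold lower number from compound 3 to compound 4 (0.25 log units; within the scatter)), so among these four compounds the two groups carrying a five-membered aromatic ring with nitrogen stand together, apart from the two phenyl groups, with no listed compound going against this.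

The compounds shown cannot separate the larger fused ring system from the ring nitrogen or its hydrogen-bond donor, since all of these enter together, and a 2-naphthyl group or a 1-methylindol-6-yl group would bear on that question. Nothing measured here gives a reason for these steps.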